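A few compounds are considered here, and "the series" means these few. Any claim that something is new, unique, unknown or untested is made for them only; others in the source may bear on it.

Measured compounds:
compound 1 `CCn1c(SC/C(=N/O)c2ccccc2)nnc1-c1cc(OC)c(OC)c(OC)c1` — 67%
compound 2 `CCn1c(SC/C(=N/O)c2ccccc2)nnc1-c1ccc(OC)c(OC)c1` — 67%

In a functional assay on the whole organism (strain albino) for inhibition, with Rattus norvegicus as the target, read by paw edema, with a stated time of 2 h, at a dose of 0.28 mmol/kg by the oral route (a lower number here means less inhibition, a higher number more inhibition at the dose given (going by the name of the read-out)), compound 1 gives 67% and compound 2 gives 67%. Among the measured compounds shown here, the single measured step, no change at the digits printed from compound 1 to compound 2 (within the scatter), shows that hydrogen in place of methoxy on an aromatic carbon left the read-out where it was. Compound 1 therefore stands level with compound 2 within the scatter.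

Compound 3 `COc1cc(-c2nnc(SC/C(=N/O)c3ccccc3)n2-c2ccccc2)cc(OC)c1OC` has not yet been measured. Compared with compound 1 the change is phenyl in place of ethyl on an aromatic nitrogen. For the measured compounds named here, this change sits on an aromatic nitrogen of the shared core, a place no measured pair touches; the one step known concerns a methoxy on an aromatic carbon and so does not speak to it. With nothing showing that a change at this nitrogen moves the read-out, the expected step is a number 7 percentage points lower from compound 1 to compound 3 (within the scatter), none beyond the scatter, with a wide range kept. Compound 3 is estimated at 60%, between 40% and 80%.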

Compound 3, a percentage reported as inhibition, in the whole organism at one dose (the size of the read-out at that dose, not a potency): 61%
Compound 3: middle estimate off by 1 percentage points, on the low side, and the stated range covers the measured number.
By their numbers in this assay, from the lowest: compounds 3, 1 and 2 (each within the scatter of the next).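

Among the compounds shown here, compound 3 gives the first reading for a change on the aromatic nitrogen of the shared core, where swapping ethyl for phenyl in this assay gives a number 6 percentage points lower from compound 1 to compound 3 (within the scatter) at the dose tested. This nitrogen, next to two ring atoms that each bear a large group, can therefore carry phenyl, with its six-membered aromatic ring, in place of the small, ringless ethyl without the paw edema inhibition moving beyond the scatter. No available evidence gives a reason for this result.

The compounds shown carry only ethyl and phenyl on this nitrogen, so the effect of a longer chain such as butyl, or of a phenyl ring bearing an amine, remains open. A reading at one dose and one time also leaves open whether compound 1 and compound 3 would match at other doses.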